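Cyclohexyl for 4-methoxyphenyl on the ring amide nitrogen

The compounds below may be only part of what the source reports. "The series", "measured", "known", "first", "only" and "open" are said of these compounds alone.

The shared scaffold carries a sulfonamide-bearing aryl group on a fused bicyclic core with a ring amide nitrogen. Compound 2 `COc1ccc(N2C(=O)COc3ccc(-c4cnc(OC)c(NS(=O)(=O)c5ccc(F)cc5)c4)cc32)cc1` gives 8260 nM in a functional assay on MCF7 cells (Homo sapiens) for antiproliferative activity, read by MTT assay, with a stated time of 72 h; on this read-out higher numbers stand for weaker inhibition and lower numbers for stronger inhibition. Compound 1 `COc1ncc(-c2ccc3c(c2)N(C2CCCCC2)C(=O)CO3)cc1NS(=O)(=O)c1ccc(F)cc1` is its counterpart with cyclohexyl in place of 4-methoxyphenyl on an amide-type nitrogen in a ring, and in this assay compound 1 gives 30100 nM, a step of a 3.6-fold higher number from compound 2 to compound 1 (0.56 log units; beyond the scatter). Compound 3 `COc1ccc(N2C(=O)COc3ccc(-c4cccc(NS(=O)(=O)c5ccc(F)cc5)c4)cc32)cc1` gives 32400 nM; the difference between the core of compound 3 and that of compound 2 is not broken down here. Compound 4 `O=C1COc2ccc(-c3cccc(NS(=O)(=O)c4ccc(F)cc4)c3)cc2N1C1CCCCC1` carries the same change as compound 1 relative to its parent, namely (cyclohexyl in place of 4-methoxyphenyl on an amide-type nitrogen in a ring), and is not yet measured. Among the measured compounds shown here, from the single earlier step, compound 4 is expected to fall by a 3.1-fold higher number from compound 3 to compound 4 (0.49 log units; beyond the scatter) from compound 3, resting on the step from compound 2 to compound 1 alone. The estimate for compound 4 is 100000 nM, between 40000 nM and 250000 nM, with a fair chance that this assay returns only a limit.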

Compound 4, half-maximal inhibitory concentration: 21400 nM
Beside the measured number, compound 4's estimate is 4.7-fold (0.67 log units) above it; the whole stated range lies above it.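

The swap of 4-methoxyphenyl for cyclohexyl on the amide-type nitrogen in a ring gives a 1.5-fold lower number from compound 3 to compound 4 (0.18 log units; within the scatter), so the loss seen on the core of compound 2 does not recur on the core of compound 3. The step therefore does not carry over from one core to the other in these two pairs: the same change on two cores in this assay, a 3.6-fold higher number (0.56 log units; beyond the scatter) from compound 2 to compound 1 and a 1.5-fold lower number (0.18 log units; within the scatter) from compound 3 to compound 4, 5.5-fold (0.74 log units) apart, beyond the scatter of two such steps

Two pairs do not show which feature of the cores sets this difference, nor how the change would read on any further core.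

Still open, on these data alone, is how a small methyl, or a chain ending in an amine, on the same nitrogen would read on either core. A third core carrying both the cyclohexyl and the 4-methoxyphenyl pair would show whether the core of compound 2 is the exception.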